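The source may report more compounds than this note shows. Statements on the series, on what has been measured and on what is new or still open speak of the compounds shown alone.

Measured compounds:
compound 1, `Cn1c(-c2ccccc2)nc2c(NC3CCCC3)ncnc21`: 2.8 nM
compound 2, `CCn1c(-c2ccccc2)nc2c(NC3CCCC3)ncnc21`: 3.9 nM
compound 3, `CCn1c(-c2ccccc2)nc2c(N)ncnc21`: 31 nM

In an assay on CHO cells for displacement of a labelled ligand from adenosine receptor A1 (Homo sapiens), read by scintillation counting, with a stated time of 3 h (a higher number here means a weaker inhibitor, a lower number a stronger inhibitor), compound 1 gives 2.8 nM, the lowest of the three numbers. Its nearest neighbour is compound 2, and the step there is small: a 1.4-fold higher number from compound 1 to compound 2 (0.14 log units; within the scatter). The furthest is compound 3, and the larger part of that gap comes lower down the series: a 7.9-fold higher number from compound 2 to compound 3 (0.90 log units; beyond the scatter).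

Compound 4, `Cc1cccc(-c2nc3c(NC4CCCC4)ncnc3n2C)c1`, differs from compound 1 in one place: methyl in place of hydrogen on an aromatic carbon. For the measured compounds named here, none of the measured steps alters the phenyl ring, so no direct precedent exists. Going by the values given here, the one step that adds a methyl, on a saturated chain carbon bound to an aromatic nitrogen, stayed within the scatter, while the only step beyond the scatter removed the cyclopentyl on a nitrogen on an aromatic ring, which compound 4 keeps intact. On that basis the author expects no step beyond the scatter from compound 1 to compound 4 in this assay, that is a 1.1-fold higher number from compound 1 to compound 4 (0.06 log units; within the scatter). The estimate for compound 4 in this assay is therefore 3.2 nM, with a range from 1.2 nM to 9 nM.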

Compound 4, inhibition constant: 6.2 nM
Beside the measured number, compound 4's estimate is 1.9-fold (0.29 log units) below it, within the range that was stated.
By their numbers in this assay, from the lowest: compounds 1, 2 and 4 (each within the scatter of the next, the first and the last beyond it); then compound 3.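

In this assay, for the compounds shown here, the phenyl ring proves sensitive to a small change: 3-methylphenyl in place of phenyl gives a 2.2-fold higher number from compound 1 to compound 4 (0.35 log units; beyond the scatter) and so marks the first measured step at this ring, a modest one but beyond the scatter. The size of a methyl alone therefore does not settle the outcome in this series, since the methyl added on a saturated chain carbon bound to an aromatic nitrogen gave only a 1.4-fold higher number from compound 1 to compound 2 (0.14 log units; within the scatter) and stayed within the scatter, whereas the one added here, on an aromatic carbon meta to a large group, did not. Nothing available on these compounds accounts for this difference between the two places.

The compounds shown leave open whether the step belongs to the methyl itself or to this particular place, as a chlorine atom, a methoxy group or a longer chain such as ethyl on the same carbon, or a methyl on another carbon of the ring, could each give a different number. They also leave open whether the same change would give a step of similar size on the ethyl-bearing compound 2 or on compound 3, which lacks the cyclopentyl group.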